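From cyclopentylsulfanyl to benzylsulfanyl on a shared core

The compounds below may be only part of what the source reports. "The series", "measured", "known", "first", "only" and "open" are said of these compounds alone.

- Compound 1 `CN(C)c1nc(N)nc2c1ncn2/C=C1/CC1(CO)CO` gives > 24000 nM (a limit)
- Compound 2 `CCCCCCSc1nc(N)nc2c1ncn2/C=C1/CC1(CO)CO` gives > 20000 nM (a limit)
- Compound 3 `Nc1nc(SC2CCCC2)c2ncn(/C=C3/CC3(CO)CO)c2n1` gives > 20000 nM (a limit)

In an ADME assay on Akata cells (Homo sapiens) for cytotoxicity, with a stated time of 7 days (a lower number here means that less compound is tolerated, a higher number that more compound is tolerated), all three values are limits and not numbers. Compound 3 stands at the limit of > 20000 nM in this assay, at which 2 of the 3 values shown sit, and so has no readable rank among the others. Compound 1 stands at the limit of > 24000 nM in this assay, at which 1 of the 3 values shown sits, on its own.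

The change to compound 4 `Nc1nc(SCc2ccccc2)c2ncn(/C=C3/CC3(CO)CO)c2n1` is benzyl in place of cyclopentyl on a sulfur. The closest measured change is a step that the two limits leave unreadable from compound 2 to compound 3 (cyclopentyl in place of hexyl on a sulfur). The other two are a step that the two limits leave unreadable from compound 1 to compound 2 and a step that the two limits leave unreadable from compound 1 to compound 3 and they give no size either. For the measured compounds named here, no measured step therefore offers a size to carry over, so no step beyond the scatter is expected in this assay and no direction can be named.

The expected outcome is a number no higher from compound 3 to compound 4 (the limit leaves the size open) (an estimate). Compound 4 is estimated at 20000 nM with an expected range from 8000 nM to 30000 nM (it may well be reported only as a limit).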

Compound 4, half-maximal cytotoxic concentration: > 20000 nM
Compound 4: only a limit was reported; the forecaster's own chance of this, stated with the estimate: 70%; the middle value lies on the limit itself.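

Compound 4 is reported in this assay as > 20000 nM, a limit and not a number. For the compounds shown here, no step from compound 1, compound 2 or compound 3 to compound 4 can be read. The compounds shown leave open at what concentration any of them becomes cytotoxic to these cells.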